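The source may report more compounds than this note shows. Statements on the series, on what has been measured and on what is new or still open speak of the compounds shown alone.

Compound 1 `Cc1ccc2nc(Nc3nc(Nc4ccc(S(N)(=O)=O)cc4)ncc3F)sc2c1` gives 4960 nM in a functional assay on PC-3 cells (Homo sapiens) for antiproliferative activity, read by MTT assay, with a stated time of 48 h; a higher number here means a weaker inhibitor, a lower number a stronger inhibitor. Compound 2 `NS(=O)(=O)c1ccc(Nc2nccc(Nc3nc4ccccc4s3)n2)cc1` gives 3100 nM in this assay.

Of these two numbers, compound 2 has the smaller one, but the gap to compound 1 falls within the usual scatter, so the two cannot be told apart. Compound 3 `Cc1ccc2nc(Nc3ccnc(Nc4ccc(S(N)(=O)=O)cc4)n3)sc2c1` differs from compound 2 by methyl in place of hydrogen on an aromatic carbon. Within the data shown here, no measured pair shows this change on its own, so no step can be read off; a change of this size is expected to stay within the scatter, in no particular direction. Compound 3 is therefore expected to give about 3000 nM, between 1200 nM and 7500 nM, an estimated step of a 1.0-fold lower number from compound 2 to compound 3 (0.01 log units; within the scatter).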

Compound 3, half-maximal inhibitory concentration: 1640 nM
Compound 3: the middle estimate sits 1.8-fold (0.26 log units) above what was measured, within the range that was stated.
By their numbers in this assay, from the lowest: compounds 3, 2 and 1 (each within the scatter of the next, the first and the last beyond it).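

On the carbon that carries it, methyl in place of hydrogen gives no readable change in this assay (a 1.9-fold lower number from compound 2 to compound 3 (0.28 log units; within the scatter)). Among these compounds, the fluoro is a different matter: with the methyl present in both compounds, hydrogen in place of fluoro gives the first step here that lies beyond the scatter, though a modest one (a 3.0-fold lower number from compound 1 to compound 3 (0.48 log units; beyond the scatter)). Nothing available explains either step.

As far as these compounds go, it remains open whether the fluoro step holds without the methyl. An ethyl group or an amine on the methyl's carbon might also behave differently.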